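The compounds below may be only part of what the source reports. "The series", "measured", "known", "first", "only" and "open" are said of these compounds alone.

Measured compounds:
Compound 1, `O=S(=O)(NCCCNCc1cccc2ccccc12)c1cc(C(F)(F)F)cc(C(F)(F)F)c1`: 21000 nM
Compound 2, `CC(C)(C)c1ccc(CNCCCNS(=O)(=O)c2cc(C(F)(F)F)cc(C(F)(F)F)c2)cc1`: 2700 nM
Compound 3, `COc1ccccc1CNCCCNS(=O)(=O)c1cc(C(F)(F)F)cc(C(F)(F)F)c1`: 4600 nM

In a functional assay on ASPC1 cells (Homo sapiens) for inhibition, read by MTT assay, with a stated time of 72 h (on this read-out lower numbers stand for stronger inhibition of growth and higher numbers for weaker inhibition of growth), compound 1 stands highest of the three numbers; the nearest value is that of compound 3 and the furthest that of compound 2. Both measured steps away from compound 1 lie beyond the scatter: a 4.6-fold lower number from compound 1 to compound 3 (0.66 log units; beyond the scatter) and a 7.8-fold lower number from compound 1 to compound 2 (0.89 log units; beyond the scatter). Between the two phenyl-bearing compounds the difference is small, a 1.7-fold higher number from compound 2 to compound 3 (0.23 log units; within the scatter).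

Compound 4, `COc1ccc(CNCCCNS(=O)(=O)c2cc(C(F)(F)F)cc(C(F)(F)F)c2)cc1`, has not yet been measured in this assay. It differs from compound 1 in one place: 4-methoxyphenyl in place of naphthalen-1-yl on a saturated chain carbon bound to an amine nitrogen. The two measured steps bear directly on this change, since each likewise exchanges the naphthalen-1-yl group for a substituted phenyl ring on a saturated chain carbon bound to an amine nitrogen, and each lowered the number modestly and beyond the scatter. A 4-methoxyphenyl group is not identical to either of those substituents, so the exact size is open, but a modest step towards a lower number is expected, with a range wide enough to cover both measured examples. Compound 4 is therefore expected to give 3800 nM in this assay, with a range from 1500 nM to 10000 nM. This estimate means an expected step of a 5.5-fold lower number from compound 1 to compound 4 (0.74 log units; beyond the scatter).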

Compound 4, concentration for 50% growth inhibition: 2800 nM
Compound 4: middle estimate off by 1.4-fold (0.13 log units), on the high side, within the range that was stated.
By their numbers in this assay, from the lowest: compounds 2, 4 and 3 (each within the scatter of the next); then compound 1.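

In this assay, 4-methoxyphenyl becomes a third single-ring group that departs from naphthalen-1-yl on a saturated chain carbon bound to an amine nitrogen by more than the scatter (a 7.5-fold lower number from compound 1 to compound 4 (0.88 log units; beyond the scatter)), so among the compounds shown, naphthalen-1-yl stands alone, and compounds 2, 3 and 4 all go the same way from compound 1. The new compound also shows that neither of two further changes separates the single-ring compounds: the exchange of 2-methoxyphenyl for 4-methoxyphenyl (a 1.6-fold lower number from compound 3 to compound 4 (0.22 log units; within the scatter)) and the exchange of tert-butyl for methoxy on an aromatic carbon (a 1.0-fold higher number from compound 2 to compound 4 (0.02 log units; within the scatter)) both stay within the scatter. Nothing available explains why the single-ring compounds part from compound 1 or why they sit together.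

On these data alone, whether an unsubstituted phenyl ring, a pyridine ring or a naphthalen-2-yl group would sit with compounds 2, 3 and 4 or with compound 1 remains open. The compounds shown also leave open how a longer chain between the two nitrogens, or chlorine in place of the trifluoromethyl groups, would affect the number.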